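The source may report more compounds than this note shows. Statements on the series, on what has been measured and on what is new or still open speak of the compounds shown alone.

Measured so far in a functional assay on HSC-3 cells (Homo sapiens) for cytotoxicity; a higher number here means that more compound is tolerated, a lower number that less compound is tolerated:
compound 1, `O=C1/C(=C/c2ccc(O)cc2)CCC/C1=C\c1ccc([N+](=O)[O-])cc1`: 13000 nM
compound 2, `O=C1/C(=C/c2ccc(O)cc2)Cc2ccccc2/C1=C\c1ccc([N+](=O)[O-])cc1`: 14000 nM

Compound 1 stands at the lowest of the two numbers in this assay, and compound 2 sits within the scatter of it, so these two values show no separation that can be read as a real gap. Compound 3, `O=C1/C(=C/c2ccc(Cl)cc2)CCC/C1=C\c1ccc([N+](=O)[O-])cc1`, has not yet been measured in this assay. It differs from compound 1 in one place: chloro in place of hydroxy on an aromatic carbon. The change sits on an aromatic carbon of a six-membered aromatic ring of carbon only, para to a large group; cut one bond further out it reads 4-hydroxyphenyl to 4-chlorophenyl. Within the data shown here, no measured pair in this set carries the same change, so there is no step to lean on, and the two values that exist give no hint of how this position responds. The expectation for compound 3 is a step of a 1.1-fold lower number from compound 1 to compound 3 (0.03 log units; within the scatter), that is, no move beyond the scatter in either direction. Compound 3 is therefore estimated at 12000 nM in this assay, with a range from 4000 nM to 35000 nM.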

Compound 3, half-maximal cytotoxic concentration: 4600 nM
Compound 3: middle estimate off by 2.6-fold (0.42 log units), on the high side; the measured number falls inside the stated range.
By their numbers in this assay, from the lowest: compound 3; then compounds 1 and 2 (each within the scatter of the next).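

In this assay, chloro in place of hydroxy on an aromatic carbon, para to a large group, gives a 2.8-fold lower number from compound 1 to compound 3 (0.45 log units; beyond the scatter) and so shows that this position is not silent: less compound is tolerated with the 4-chlorophenyl group than with the 4-hydroxyphenyl group. Among these compounds, the step is modest and rests on a single pair, and the hydrogen-bond donor and acceptor that leave with the hydroxy cannot be separated here from the arrival of the chlorine, so the pair shows only that the exchange as a whole moves the number beyond the scatter. Nothing at hand bears on why the number moves.

Still open, from the compounds shown here alone, is whether the step follows the halogen itself or simply the loss of hydroxy, which a comparison with fluoro, methoxy, an amine or a carboxylic acid at the same position could help to settle. Equally open, going by these compounds, is whether the same exchange gives a step of similar size on the core of compound 2, whose value stands within the scatter of that of compound 1 and so offers no guidance on this point.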